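Replacing a urea end group with benzyl: expected stability

The source may report more compounds than this note shows. Statements on the series, on what has been measured and on what is new or still open speak of the compounds shown alone.

Measured so far:
- compound 1 `CC(C)(C)OC(=O)NCCS(=O)(=O)NC(=O)c1ccc(Nc2nc(NC3(c4ccc(Cl)cc4)CC3)nc(OCC(F)(F)F)n2)cc1`: 92%
- compound 2 `CNC(=O)NCCS(=O)(=O)NC(=O)c1ccc(Nc2nc(NC3(c4ccc(Cl)cc4)CC3)nc(OCC(F)(F)F)n2)cc1`: 97%

Both compounds were tested in an ADME assay on microsomes from liver (Homo sapiens) for metabolic stability, with a stated time of 10 min; a higher number here means that more of the compound is left, a lower number that less of the compound is left. Among the measured compounds shown here, compound 2 gives 97%, and it stands at the top of the two numbers, but its only neighbour, compound 1, is close: the step of a number 5 percentage points higher from compound 1 to compound 2 (within the scatter) lies within the scatter, so the two cannot be ranked.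

Compound 3 `O=C(NS(=O)(=O)CCNCc1ccccc1)c1ccc(Nc2nc(NC3(c4ccc(Cl)cc4)CC3)nc(OCC(F)(F)F)n2)cc1` has not yet been measured. It differs from compound 2 by benzyl in place of methylcarbamoyl on an amine nitrogen. For the measured compounds named here, the one measured step, a number 5 percentage points higher from compound 1 to compound 2 (within the scatter), concerns a different place, a carbonyl carbon, and was small; no measured step touches the amine nitrogen or brings in an aromatic ring at that position. The data therefore give no direct guide, and the expectation rests on the absence of evidence rather than on a shown trend.

The estimate for compound 3 is 78%, with a range from 50% to 97%. This expected step, a number 19 percentage points lower from compound 2 to compound 3 (beyond the scatter), is a downward guess with wide uncertainty.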

Compound 3, percent of the compound remaining: 99%
Estimate against measurement, compound 3: 21 percentage points below; the measured number lies above the stated range.
By their numbers in this assay, from the lowest: compounds 1, 2 and 3 (each within the scatter of the next).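

In this assay, benzyl in place of methylcarbamoyl on the amine nitrogen gives a step that is small (a number 2 percentage points higher from compound 2 to compound 3 (within the scatter)), and benzyl in place of tert-butoxycarbonyl on the same nitrogen gives another small one (a number 7 percentage points higher from compound 1 to compound 3 (within the scatter)). The earlier pair differed only in the group on a carbonyl carbon, whereas these two steps show that the whole carbonyl-bearing end group on this nitrogen can be exchanged for a benzyl group, with its six-membered aromatic ring of carbon only and no hydrogen-bond donors or acceptors, without any step beyond the scatter. No measurement offered here says why the numbers for these three different end groups lie so close together.

All three compounds therefore remain unranked by this read-out, so it cannot yet separate one end group from another at this position. Still open, on these data alone, is how a carboxylic acid, a free primary amine or a longer chain on this amine nitrogen would read in this assay, and whether any such group would give a step beyond the scatter.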